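Chloro Beside Fluorosulfonyl: a Repeated Step in Two Series

This account rests on a few compounds, and the source may have more. Where it says the series, first, only, none or still open, it means among the compounds named here.

The measured compounds:
compound 1, `CC1(C)N=C(N)N=C(N)N1c1ccc(OCc2ccc(S(=O)(=O)F)cc2)c(Cl)c1`, 7.58;
compound 2, `CC1(C)N=C(N)N=C(N)N1c1ccc(CCCCc2ccccc2S(=O)(=O)F)c(Cl)c1`, 7.77;
compound 3, `CC1(C)N=C(N)N=C(N)N1c1ccc(OCc2ccc(S(=O)(=O)F)c(Cl)c2)c(Cl)c1`, 7.43.

All three were tested in an assay on isolated protein for inhibition of Dihydrofolate reductase (Mus musculus); a lower number here means a less potent compound, a higher number a more potent compound, by a factor of ten per unit of this negative logarithm. Compound 1 and compound 3 differ by one change, (chloro in place of hydrogen on an aromatic carbon), and the step in this assay was a number 0.15 log units lower from compound 1 to compound 3 (within the scatter). Compound 2 carries a different core; how it differs from compound 1 is not broken down here. Its value stands above that of compound 1 within the scatter and above that of compound 3 beyond the scatter.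

Compound 4, `CC1(C)N=C(N)N=C(N)N1c1ccc(CCCCc2cccc(Cl)c2S(=O)(=O)F)c(Cl)c1`, has not yet been measured. It differs from compound 2 by chloro in place of hydrogen on an aromatic carbon, the same change as from compound 1 to compound 3. Resting on a number 0.15 log units lower from compound 1 to compound 3 (within the scatter), the step is expected to be a number 0.15 log units lower from compound 2 to compound 4 (within the scatter), so compound 4 is estimated at 7.62, between 7.3 and 7.95.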

Compound 4, logarithm of the reciprocal of the active concentration, log(1/C): 8.2
Compound 4: middle estimate off by 0.58 log units, on the low side, outside the stated range (above it).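

In this assay, chloro in place of hydrogen on an aromatic carbon gave a number 0.43 log units higher from compound 2 to compound 4 (beyond the scatter). The change therefore did not carry over as a constant step between these two cores: the same change on two cores in this assay, a number 0.15 log units lower (within the scatter) from compound 1 to compound 3 and a number 0.43 log units higher (beyond the scatter) from compound 2 to compound 4, 0.58 log units apart, beyond the scatter of two such steps. This shows that the step seen on one core was a poor guide to the step on the other, but with one pair on each core it does not show why the two differ or what the change would do on a further core.

The compounds shown leave open whether a fluoro or a methyl group ortho to a fluorosulfonyl group would follow the chloro step on the core of compound 2. They also leave open whether a shorter chain in that core would keep the step seen there.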